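The compounds below may be only part of what the source reports. "The series", "measured", "known", "first", "only" and "open" are said of these compounds alone.

Three compounds share a long oxygen-linked chain joining two aromatic parts, and they differ at the ends of that chain. Compound 1 `CCCC(=O)c1ccc(OCCCCOc2cccc(C(=O)O)c2C)c(C)c1O` carries a ketone bearing a propyl group. In an assay on HEK293 cells for positive allosteric modulation of metabotropic glutamate receptor 2 (Rattus norvegicus), read by thallium flux, with a stated time of 2.5 min (on this read-out lower numbers stand for smaller maximal responses and higher numbers for larger maximal responses), compound 1 reaches 82.4%. Compound 2 `CCC(=O)c1ccc(OCCCCOc2cccc(C(=O)O)c2C)c(C)c1O` differs from it only by hydrogen in place of methyl on a saturated chain carbon, two bonds along the chain from a carbonyl carbon, and in this assay compound 2 reaches 71.3%; the step is a number 11.1 percentage points lower from compound 1 to compound 2 (beyond the scatter). Compound 3 `CCC(=O)c1ccc(OCCCCOc2ccc(C(=O)O)cc2C)c(C)c1O` carries the same propanoyl group as compound 1 on a different core; the difference between the two cores is not broken down here. In this assay compound 3 gives 86.6%, which lies within the scatter of the value of compound 1 and beyond the scatter of the value of compound 2.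

Compound 4 `CC(=O)c1ccc(OCCCCOc2ccc(C(=O)O)cc2C)c(C)c1O` is obtained from compound 3 by hydrogen in place of methyl on a saturated chain carbon bound to a carbonyl carbon. Among the compounds with values here, this is the same kind of change as the one from compound 1 to compound 2, but not the same: there the carbon that loses the methyl sits two bonds along the chain from a carbonyl carbon, here it is bound to a carbonyl carbon. Shortening the chain by one carbon lowered the maximal response modestly once, so a step of similar size, a number 10.6 percentage points lower from compound 3 to compound 4 (beyond the scatter), is expected for compound 4, resting on the drop seen in a number 11.1 percentage points lower from compound 1 to compound 2 (beyond the scatter). The estimated value for compound 4 in this assay is 76%, expected to fall between 62% and 90%.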

Compound 4, largest response reached (reported as percent of maximum), in percent of the reference or control that the assay uses: 83.1%
For compound 4 the middle estimate is 7.1 percentage points below the measured one; the measured number falls inside the stated range.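

In this assay, the swap from propanoyl to acetyl gives a number 3.5 percentage points lower from compound 3 to compound 4 (within the scatter). Set beside the earlier shortening of the ketone chain on the other core, this step cannot be told apart from it: the same change on two cores in this assay, a number 11.1 percentage points lower (beyond the scatter) from compound 1 to compound 2 and a number 3.5 percentage points lower (within the scatter) from compound 3 to compound 4, 7.6 percentage points apart, within the scatter of two such steps The data therefore give no sign that the core alters the effect of removing this methyl, although one step lies beyond the scatter and the other within it; they do not show that the effect carries over unchanged, since only two pairs are available and the carbon that loses its methyl is not the same one in each pair.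

The compounds shown leave open what a longer chain on the ketone, such as pentanoyl, or an amine-derived amide in place of the ketone would give on either core. They also leave open how the maximal response would respond if the carboxylic acid were replaced by a methyl ester or a tetrazole, or if the oxygen-linked chain joining the two aromatic parts were made shorter or longer.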